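Benzamidomethyl in place of 4-fluorophenyl: what to expect

This account rests on a few compounds, and the source may have more. Where it says the series, first, only, none or still open, it means among the compounds named here.

Measured in a functional assay on MCF7 cells (Homo sapiens) for inhibition, read by MTT assay, with a stated time of 72 h; on this read-out higher numbers stand for weaker inhibition and lower numbers for stronger inhibition:
compound 1 `Fc1ccc(-c2nnc(SCCCN3CCN(c4nc5ccccc5o4)CC3)o2)cc1`: 52300 nM
compound 2 `CC(C)(C)Oc1ccc(-c2nnc(SCCCN3CCN(c4nc5ccccc5o4)CC3)o2)cc1`: 94900 nM
compound 3 `Fc1ccc(-c2nnc(SCCCN3CCN(c4nc5ccccc5s4)CC3)o2)cc1`: 84100 nM

In this assay compound 3 gives 84100 nM, a number within the scatter of those of both compound 1 and compound 2, so the three are not separated.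

Compound 4 `O=C(NCc1nnc(SCCCN2CCN(c3nc4ccccc4s3)CC2)o1)c1ccccc1` has benzamidomethyl in place of 4-fluorophenyl on an aromatic carbon of a five-membered aromatic ring with 2 nitrogen and 1 oxygen (benzamidomethyl in place of 4-fluorophenyl on an aromatic carbon). Within the data shown here, no measured compound carries benzamidomethyl, so the data hold no direct measure of this change.

Two measured steps give the nearest guidance. Tert-butoxy in place of fluoro on an aromatic carbon gives a 1.8-fold higher number from compound 1 to compound 2 (0.26 log units; within the scatter). Exchanging 1,3-benzoxazol-2-yl for 1,3-benzothiazol-2-yl gives a 1.6-fold higher number from compound 1 to compound 3 (0.21 log units; within the scatter). Neither step removes the 4-fluorophenyl group as a whole, so both bear on the change only indirectly. Resting on these two small steps and on compound 3 at 84100 nM, no step beyond the scatter is expected in this assay, and no firm direction can be expected either.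

The expected step is a 1.2-fold lower number from compound 3 to compound 4 (0.08 log units; within the scatter). Compound 4 is estimated at 70000 nM, with an expected range from 25000 nM to 160000 nM.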

Compound 4, half-maximal inhibitory concentration: 39000 nM
Compound 4: the middle estimate sits 1.8-fold (0.25 log units) above what was measured; measured number inside the range.
By their numbers in this assay, from the lowest: compounds 4, 1, 3 and 2 (each within the scatter of the next, the first and the last beyond it).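

In this assay, benzamidomethyl in place of 4-fluorophenyl gives a 2.2-fold lower number from compound 3 to compound 4 (0.33 log units; beyond the scatter), a modest change but the first step among these compounds to lie beyond the scatter. The result shows that this position, on an aromatic carbon of the five-membered aromatic ring with 2 nitrogen and 1 oxygen, does not depend on keeping 4-fluorophenyl: the group can leave as a whole, and a larger group bearing an amide, with a hydrogen-bond donor and a hydrogen-bond acceptor, can take its place without a rise in the number. No measurement among the data presented here accounts for this step.

As far as these compounds go, the exchange alters several features at once, so it remains open whether the amide hydrogen, the carbonyl or the terminal phenyl ring carries the step, and a plain benzyl group, an amide with a methyl group on its nitrogen or a longer chain between the amide and the ring would help to separate them. From the compounds shown here alone, it is also open whether benzamidomethyl gives a similar step when 1,3-benzoxazol-2-yl replaces 1,3-benzothiazol-2-yl on the ring amine nitrogen.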